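The compounds below may be only part of what the source reports. "The series", "measured", "known", "first", "only" and "open" are said of these compounds alone.

Measured compounds: compound 1 `COc1cc2ncnc(Nc3ccc(F)c(Cl)c3)c2cc1OCCn1ccnc1[N+](=O)[O-]`, compound 2 `COc1cc2ncnc(Nc3cccc(Br)c3)c2cc1OCCCn1ccnc1[N+](=O)[O-]`, compound 3 `C#Cc1cccc(Nc2ncnc3cc(OC)c(OCCCn4ccnc4[N+](=O)[O-])cc23)c1`.

In a functional assay on HT-29 cells (Homo sapiens) for cytotoxicity, read by sulforhodamine B assay, with a stated time of 72 h (on this read-out lower numbers stand for stronger inhibition and higher numbers for weaker inhibition), compound 2 gives 4480 nM, the lowest of the two numbers shown. Compound 3 gives 5550 nM, and the step of a 1.2-fold higher number from compound 2 to compound 3 (0.09 log units; within the scatter) lies within the scatter. For compound 1 this assay reports only a limit, > 50000 nM, so no number is known for it (the limit of > 50000 nM in this assay, at which 1 of the 3 values shown sits).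

Compound 4 `COc1cc2ncnc(Nc3cccc(Br)c3)c2cc1OCCCn1c([N+](=O)[O-])cnc1C` differs from compound 2 in one place: 2-methyl-5-nitro-1H-imidazol-1-yl in place of 2-nitro-1H-imidazol-1-yl on a saturated chain carbon, three bonds along the chain from an oxygen on an aromatic ring. Going by the values given here, none of the measured steps touches this part of the molecule, so no step on record bears directly on the change. The estimate for compound 4 therefore rests on compound 2 alone and is expected to stay near it, with the step of a 1.1-fold higher number from compound 2 to compound 4 (0.05 log units; within the scatter) anticipated to remain within the scatter. Compound 4 is thus estimated at 5000 nM, with a range from 2000 nM to 15000 nM.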

Compound 4, half-maximal inhibitory concentration: 15700 nM
The estimate for compound 4 lay 3.1-fold (0.50 log units) below the measured number; the whole stated range lies below it.
By their numbers in this assay, from the lowest: compounds 2 and 3 (each within the scatter of the next); then compound 4. At a limit, above all of these: compound 1.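

In this assay, going by these compounds alone, the group on the saturated chain carbon, three bonds along the chain from an oxygen on an aromatic ring, proves able to move the number: 2-methyl-5-nitro-1H-imidazol-1-yl in place of 2-nitro-1H-imidazol-1-yl gives a 3.5-fold higher number from compound 2 to compound 4 (0.54 log units; beyond the scatter), whereas the only earlier step, ethynyl in place of bromo, stayed within the scatter. Nothing on record bears on why this step occurs.

The compounds shown do not separate the added methyl from the changed place of the nitro group. From the compounds shown here alone, how an amine in place of the nitro group would read remains open.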